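Methoxy in place of hydrogen: cytotoxicity in RD cells

The compounds below may be only part of what the source reports. "The series", "measured", "known", "first", "only" and "open" are said of these compounds alone.

Compound 1, `Cc1nc(-c2cnc3ccc(-c4ccc(N)cc4)cc3c2)no1` — in a functional assay on RD cells (Homo sapiens) for inhibition, read by luminescence and ATP content, with a stated time of 72 h (on this read-out higher numbers stand for lower toxicity in this test and lower numbers for higher toxicity in this test), compound 1 gives > 2500 nM, a limit of the assay.
Compound 2, `CCCc1ccc(-c2ccc3ncc(-c4noc(C)n4)cc3c2)cc1` — in this assay compound 2 gives > 7400 nM, a limit of the assay.
Compound 3, `Cc1nc(-c2cnc3ccc(-c4ccccc4)cc3c2)no1` — in this assay compound 3 gives > 2500 nM, a limit of the assay.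

Compound 3 thus stands at a limit and not at a number, and the same is true of the two other compounds shown. Compound 4, `COc1ccc(-c2ccc3ncc(-c4noc(C)n4)cc3c2)cc1`, differs from compound 3 by methoxy in place of hydrogen on an aromatic carbon. The steps that could bear on this change, a step that the two limits leave unreadable from compound 1 to compound 2, a step that the two limits leave unreadable from compound 1 to compound 3 and a step that the two limits leave unreadable from compound 2 to compound 3, all run between limits and so give no readable size; two of the values sit at the limit of > 2500 nM in this assay, at which 2 of the 3 values shown sit, and one at the limit of > 7400 nM in this assay, at which 1 of the 3 values shown sits. No step beyond the scatter is therefore expected in this assay, in either direction. Compound 4 is estimated at 6000 nM, within a range from 2000 nM to 20000 nM, most likely reported once more only as a limit. The expected step from compound 3 to compound 4 is a step that the limit leaves unreadable from compound 3 to compound 4.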

Compound 4, half-maximal cytotoxic concentration: > 66700 nM
Compound 4: only a limit was reported (the forecaster's own chance of this, stated with the estimate: 80%); middle value at least 11-fold (1.04 log units) from the limit.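

In this assay compound 4 gives > 66700 nM, a limit of the assay. Its steps from compound 1, compound 2 and compound 3 all run between limits and cannot be read. The compounds shown leave open whether hydrogen, amino, propyl or methoxy at this place differ in cytotoxic concentration at all.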